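The source may report more compounds than this note shows. Statements on the series, on what has been measured and on what is new or still open speak of the compounds shown alone.

Measured compounds:
Compound 1 `Cc1ccccc1-c1nc(CN2CCC(C(=O)NCCCN3CC(C)(C)CC(C)(C)C3)CC2)c(C)o1`: > 1390 10^-6 cm/s
Compound 2 `Cc1oc(-c2ccc(Cl)c(Cl)c2)nc1CN1CCC(C(=O)NCCCN2C[C@H](C)C[C@H](C)C2)CC1`: 522 10^-6 cm/s

In a physicochemical assay for permeability, using PAMPA (on this read-out higher numbers stand for higher permeability and lower numbers for lower permeability), compound 1 gives > 1390 10^-6 cm/s, which is a limit of the assay and not a number. Compound 2 gives 522 10^-6 cm/s in this assay. Among the measured compounds shown here, no step between measured compounds that differ in a single place is available here, so compound 1 stands only as one of the values sitting at the limit of > 1390 10^-6 cm/s in this assay, at which 1 of the 2 values shown sits, with no step of known size to lean on. Compound 3 `Cc1ccccc1-c1nc(CN2CCC(C(=O)NCCCN3CC4CCCC(C4)C3)CC2)c(C)o1` is not yet measured in this assay. It differs from compound 1 by a group of 9 heavy atoms (8 carbon, 1 nitrogen; one six-membered non-aromatic ring of carbon only, one six-membered non-aromatic ring with 1 hetero atom) in place of a group of 10 heavy atoms (9 carbon, 1 nitrogen; one six-membered non-aromatic ring with 1 hetero atom), on a saturated chain carbon, three bonds along the chain from an amide-type nitrogen. Because compound 1 already sits at the limit of > 1390 10^-6 cm/s in this assay, at which 1 of the 2 values shown sits, the expected step of an at least 1.1-fold lower number from compound 1 to compound 3 (0.06 log units; that floor lies within the scatter) is small, within the usual scatter or at most a modest decline. Compound 3 is therefore estimated to give about 1200 10^-6 cm/s in this assay, with a likely range from 500 10^-6 cm/s to 1600 10^-6 cm/s, and a fair chance that only a limit is reported again.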

Compound 3, apparent permeability: 331 10^-6 cm/s
Compound 3: middle estimate off by 3.6-fold (0.56 log units), on the high side; the measured number lies below the stated range.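

At this place, on a saturated chain carbon, three bonds along the chain from an amide-type nitrogen, exchanging the group of 10 heavy atoms for the group of 9 heavy atoms, which adds a six-membered non-aromatic ring of carbon only, is not a silent change in this assay: it gives an at least 4.1-fold lower number from compound 1 to compound 3 (0.62 log units; beyond the scatter). Compound 1 gives > 1390 10^-6 cm/s, which is a limit of the assay and not a number. The step is thus a floor, beyond the scatter, and its full size stays unknown because it starts from a limit: the limit of > 1390 10^-6 cm/s in this assay, at which 1 of the 3 values shown sits.

The compounds shown do not tell whether a simpler group at this place, such as a morpholine or an unsubstituted piperidine, would give a number nearer to that of compound 3 or to the limit of compound 1. They also leave open whether the same exchange would give a step of similar size with a dichlorophenyl group in place of the methylphenyl group.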